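A Tetrazole in Place of a Diethylamide

The source may report more compounds than this note shows. Statements on the series, on what has been measured and on what is new or still open speak of the compounds shown alone.

Measured compounds:
- compound 1 `CCN(CC)C(=O)c1ccc(NC(=O)C(C)(O)C(F)(F)F)cc1`: in an assay on a protein complex (Cavia porcellus) with sulfonylurea receptors; K-ATP channels (Homo sapiens) as the target (on this read-out lower numbers stand for stronger inhibition and higher numbers for weaker inhibition), compound 1 gives > 30000 nM, a limit of the assay and not a number.
- compound 2 `CC(C)CN(CC(C)C)S(=O)(=O)c1ccc(NC(=O)C(C)(O)C(F)(F)F)cc1`: in this assay compound 2 gives > 30000 nM, again a limit.
- compound 3 `CC(O)(C(=O)Nc1ccc(/C(=N\O)c2ccccc2)cc1)C(F)(F)F`: in this assay compound 3 gives > 30000 nM, also a limit.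

Compound 1 stands at the limit and nowhere else: its value in this assay is only a limit, and the same is true of the two other compounds, as all three sit at the limit of > 30000 nM in this assay, at which 3 of the 3 values shown sit. Within the data shown here, no step between measured compounds can therefore be sized, and no gap within or beyond the scatter can be read off the numbers.

The unmeasured compound 4 `CC(O)(C(=O)Nc1ccc(-c2nn[nH]n2)cc1)C(F)(F)F` is reached from compound 1 by one change, (2H-tetrazol-5-yl in place of diethylcarbamoyl on an aromatic carbon), that is, 2H-tetrazol-5-yl in place of diethylcarbamoyl on an aromatic carbon, para to a large group. The other part of compound 1, the amide bearing the hydroxy and trifluoromethyl groups on the shared core, is kept.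

Among the measured compounds shown here, since all three measured compounds rest at the limit, the data give no direction for the step in this assay. The step from compound 1 to compound 4 is expected to be about a step that the limit leaves unreadable from compound 1 to compound 4, and compound 4 is estimated at 40000 nM, between 8000 nM and 200000 nM, with a strong chance that it too is reported only as a limit.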

Compound 4, half-maximal inhibitory concentration: > 30000 nM
Compound 4: a limit, no number; the forecaster's own chance of this, stated with the estimate: 70%; the middle value lies beyond the limit too.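

In this assay compound 4 gives > 30000 nM, a limit of the assay and not a number. Compound 1 also rests at a limit, so no step from compound 1 to compound 4 can be read: the limit of > 30000 nM in this assay, at which 4 of the 4 values shown sit.

The compounds shown leave open whether any change on the shared core would give a readable number in this assay.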